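Carbamate series on the shared core: a second chloro

The source may hold more compounds than are shown below. What is called first, only, known or untested is meant among the compounds shown, and "the series" means these compounds.

Compound 3 `CC(C)=CCC/C(C)=C/CC1Cc2c(OC(=O)Nc3ccc(Cl)cc3)cc(=O)n(CCCO)c2CC1(C)C` stands second highest of three numbers in a functional assay on PANC-1 cells (Homo sapiens) for inhibition, read by MTT assay, with a stated time of 24 h, tested at 10 uM (on this read-out higher numbers stand for more inhibition at the one concentration tested (going by the name of the read-out) and lower numbers for less inhibition), where compound 3 gives 4.3%. Compound 2 `CC(C)=CCC/C(C)=C/CC1Cc2c(OC(=O)Nc3ccc(F)cc3)cc(=O)n(CCCO)c2CC1(C)C` gives 6.2% and compound 1 `CCOc1cc(=O)n(CCCO)c2c1CC(C/C=C(\C)CCC=C(C)C)C(C)(C)C2` gives 0.8%; the steps of a number 3.5 percentage points higher from compound 1 to compound 3 (within the scatter) and a number 1.9 percentage points lower from compound 2 to compound 3 (within the scatter) both lie within the scatter, as does a number 5.4 percentage points higher from compound 1 to compound 2 (within the scatter). Compound 4 `CC(C)=CCC/C(C)=C/CC1Cc2c(OC(=O)Nc3ccc(Cl)c(Cl)c3)cc(=O)n(CCCO)c2CC1(C)C` differs from compound 3 by chloro in place of hydrogen on an aromatic carbon. Within the data shown here, no measured step exchanges hydrogen for chloro on that ring; the closest comparison is the halogen exchange a number 1.9 percentage points lower from compound 2 to compound 3 (within the scatter), and the carbamate introductions stayed within the scatter too, so no step beyond the scatter is expected. The expected step from compound 3 to compound 4 is a number 0.7 percentage points higher from compound 3 to compound 4 (within the scatter). Compound 4 is estimated at 5%, with a range from 0% to 15%.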

Compound 4, a percentage reported as inhibition, at one concentration (the size of the read-out at that concentration, not a potency): 0%
The estimate for compound 4 lay 5 percentage points above the measured number, and the stated range covers the measured number.
By their numbers in this assay, from the lowest: compounds 4, 1, 3 and 2 (each within the scatter of the next).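

Chloro in place of hydrogen, ortho to a chloro group and meta to a large group, gives the step of a number 4.3 percentage points lower from compound 3 to compound 4 (within the scatter) in this assay, so this added chloro is not separated from hydrogen at this position. The steps of a number 6.2 percentage points lower from compound 2 to compound 4 (within the scatter) and a number 0.8 percentage points lower from compound 1 to compound 4 (within the scatter) also leave the 3,4-dichlorophenyl carbamate unseparated from the compounds before it. All four readings lie close together at the one concentration tested.

As far as these compounds go, whether an amine or a carboxylic acid at this aromatic carbon would give a step beyond the scatter remains open. No evidence bearing on this result is available.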